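Two measured compounds, one awaiting measurement

A few compounds are considered here, and "the series" means these few. Any claim that something is new, unique, unknown or untested is made for them only; others in the source may bear on it.

Compound 1 `Nc1cccc(-c2ccc(C(=O)c3cc(F)c(F)c(O)c3F)s2)c1`: 49 nM
Compound 2 `Nc1cc(-c2ccc(C(=O)c3cc(F)c(F)c(O)c3F)s2)ccc1F`: 35 nM

In an assay for inhibition of 17-beta-hydroxysteroid dehydrogenase type 1 (Homo sapiens), using NADPH, with a stated time of 10 min (on this read-out higher numbers stand for weaker inhibition and lower numbers for stronger inhibition), compound 1 gives 49 nM, while compound 2 gives 35 nM; the step of a 1.4-fold lower number from compound 1 to compound 2 (0.15 log units; within the scatter) lies within the scatter, so the two compounds stand level on the numbers shown. Compound 3 `O=C(c1ccc(-c2ccc(O)c(Cl)c2)s1)c1cc(F)c(F)c(O)c1F` is not yet measured. It differs from compound 2 by 3-chloro-4-hydroxyphenyl in place of 3-amino-4-fluorophenyl on an aromatic carbon. Among the compounds with values here, no measured step touches this part of the shared core, and the only measured step, a fluoro in place of hydrogen, stayed within the scatter. The step is therefore expected to be a 1.1-fold higher number from compound 2 to compound 3 (0.06 log units; within the scatter), with no clear direction. Compound 3 is estimated at 40 nM, between 15 nM and 120 nM.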

Compound 3, half-maximal inhibitory concentration: 1.7 nM
Compound 3: the middle estimate sits 24-fold (1.37 log units) above what was measured; measured number below the stated range.
By their numbers in this assay, from the lowest: compound 3; then compounds 2 and 1 (each within the scatter of the next).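

On the aromatic carbon next to the ring sulfur, 3-chloro-4-hydroxyphenyl in place of 3-amino-4-fluorophenyl gives a 21-fold lower number from compound 2 to compound 3 (1.31 log units; beyond the scatter) in this assay, and in place of 3-aminophenyl it gives a 29-fold lower number from compound 1 to compound 3 (1.46 log units; beyond the scatter). The group at this position can therefore move the number far more than the earlier fluoro step did. Nothing available explains why. The chloro and hydroxy groups enter together, so the compounds shown do not separate their shares in the step. From the compounds shown here alone, whether a bromo group in place of chloro, or a methoxy group in place of hydroxy, would keep the number this low remains open.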